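Pendant aryl change on the fused core of compound 1

The source may hold more compounds than are shown below. What is called first, only, known or untested is meant among the compounds shown, and "the series" means these compounds.

Compound 1 `CC#CC(CC(=O)O)c1ccc(OCc2ccc3nc(-c4ccc(C(F)(F)F)cc4)cn3c2)cc1` is measured in an assay on isolated protein for agonist activity at Free fatty acid receptor 1 (Homo sapiens) (on this read-out lower numbers stand for an effect already at smaller amounts and higher numbers for an effect only at larger amounts of compound), at 558 nM, the lowest of the three numbers in hand. Within the data shown here, compound 2 `CC#CC(CC(=O)O)c1ccc(OCc2ccn3cc(-c4ccccc4)nc3c2)cc1` gives 1260 nM and compound 3 `CC#CC(CC(=O)O)c1ccc(OCc2ccn3cc(-c4cccc(C)c4)nc3c2)cc1` gives 1510 nM; both are built on a different core, so no single-point step links either to compound 1, and the values only show that compound 1 sits below each. Among the measured compounds shown here, the one measured step, a 1.2-fold higher number from compound 2 to compound 3 (0.08 log units; within the scatter), concerns methyl in place of hydrogen on an aromatic carbon and stays within the scatter.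

Compound 4 `CC#CC(CC(=O)O)c1ccc(OCc2ccc3nc(-c4ccccc4F)cn3c2)cc1` differs from compound 1 by 2-fluorophenyl in place of 4-(trifluoromethyl)phenyl on an aromatic carbon. For the measured compounds named here, this change is larger than the step between compound 2 and compound 3, which is the only precedent and which moved little. Going by the values given here, with no direct precedent for loss of the trifluoromethyl group, a modest weakening is expected, a 1.8-fold higher number from compound 1 to compound 4 (0.25 log units; within the scatter), in this assay. Compound 4 is therefore estimated at 1000 nM, with a range of 400 nM to 2500 nM.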

Compound 4, half-maximal effective concentration: 583 nM
The estimate for compound 4 lay 1.7-fold (0.23 log units) above the measured number; the range from low to high includes it.
By their numbers in this assay, from the lowest: compounds 1 and 4 (each within the scatter of the next); then compounds 2 and 3 (each within the scatter of the next).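

On the core of compound 1, the step in this assay is a 1.0-fold higher number from compound 1 to compound 4 (0.02 log units; within the scatter), so 2-fluorophenyl in place of 4-(trifluoromethyl)phenyl leaves the read-out within the scatter. Among these compounds, this is the first measured step at this position on this core, and it shows that the trifluoromethyl group is not required here to keep the number: a phenyl carrying a single fluorine serves as well in this read-out. No evidence is at hand that bears on this result.

The step changes both the substituent and its place on the phenyl ring, so these compounds do not separate the two. As far as these compounds go, how a nitrile or an amine on that phenyl ring would read on this core remains open, as does whether the core of compound 2 and compound 3 would tolerate the same exchange.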